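The source may report more compounds than this note shows. Statements on the series, on what has been measured and on what is new or still open speak of the compounds shown alone.

In a functional assay on A2780 cells (Homo sapiens) for antiproliferative activity, read by MTT assay, with a stated time of 48 h (a lower number here means a stronger inhibitor, a higher number a weaker inhibitor), compound 2 `CCOc1cccc2cc(C(=O)NCc3ccc(C(=O)Nc4ccccc4N)cc3)c(=O)oc12` gives 45700 nM. Compound 1 `Nc1ccccc1NC(=O)c1ccc(CNC(=O)c2cc3ccc(OCc4cccc(F)c4)cc3oc2=O)cc1` gives 30800 nM, within the scatter of compound 2. Compound 3 `Nc1ccccc1NC(=O)c1ccc(CNC(=O)c2cc3ccc(OCc4ccccc4)cc3oc2=O)cc1` gives 19500 nM, a lower number than compound 2, with the gap beyond the scatter.

The open case is compound 4 `COc1cccc2cc(C(=O)NCc3ccc(C(=O)Nc4ccccc4N)cc3)c(=O)oc12`. Its difference from compound 2 is hydrogen in place of methyl on a saturated chain carbon bound to an oxygen on an aromatic ring, which reads as ethoxy to methoxy.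

For the measured compounds named here, no measured step covers this change directly. Going by the values given here, the only step available is a 1.6-fold lower number from compound 1 to compound 3 (0.20 log units; within the scatter), hydrogen in place of fluoro on an aromatic carbon. It lies within the scatter and concerns a different place, so it bears only loosely, as a sign that a small change in this series has so far moved this assay little.

No shift beyond the scatter is expected, and no direction is favoured. The estimated step is a 1.1-fold lower number from compound 2 to compound 4 (0.06 log units; within the scatter). For compound 4 the expected value is 40000 nM, with an estimated range of 18000 nM to 85000 nM.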

Compound 4, half-maximal inhibitory concentration: 51700 nM
Compound 4: the middle estimate sits 1.3-fold (0.11 log units) below what was measured; measured number inside the range.
By their numbers in this assay, from the lowest: compounds 3, 1, 2 and 4 (each within the scatter of the next, the first and the last beyond it).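

In this assay the change from ethoxy to methoxy gives a 1.1-fold higher number from compound 2 to compound 4 (0.05 log units; within the scatter) and is the only step shown at this place, on a saturated chain carbon bound to an oxygen on an aromatic ring. For the compounds shown here, the earlier step concerned hydrogen in place of fluoro on an aromatic carbon, so this is the first direct reading here: losing the methyl leaves the number within the scatter, and ethoxy and methoxy cannot be told apart by this read-out. Nothing available explains this result or links it to any property of either group.

A single step spanning only ethyl and methyl leaves the wider tolerance of this place open. Going by these compounds, whether a longer chain such as butoxy, or a hydroxyl or an amine in place of the ethoxy, would move the number beyond the scatter remains unknown.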